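Benzimidazole piperazine amides: from isobutyl to a prenyl chain

The source may report more compounds than this note shows. Statements on the series, on what has been measured and on what is new or still open speak of the compounds shown alone.

Measured compounds in an assay on isolated protein for inhibition of aldehyde dehydrogenase 1A1 (Homo sapiens), read by spectrophotometry, tested at 10 uM; on this read-out lower numbers stand for less inhibition and higher numbers for more inhibition at the one concentration tested (going by the name of the read-out):
compound 1, `COc1ccc(C(=O)N2CCN(Cc3nc4ccccc4n3Cc3cccc(C)c3)CC2)cc1`, gives 55.5%
compound 2, `CC(C)Cn1c(CN2CCN(C(=O)C3CC3)CC2)nc2ccccc21`, gives 13.1%
compound 3, `Cc1cccc(Cn2c(CN3CCN(C(=O)C4CCCC4)CC3)nc3ccccc32)c1`, gives 67.5%

Compound 2 stands lowest of the three numbers in this assay; its nearest neighbour is compound 1, a number beyond the scatter higher, and the furthest is compound 3, higher still and also beyond the scatter. Compound 4, `CC(C)=CCn1c(CN2CCN(C(=O)C3CC3)CC2)nc2ccccc21`, has not yet been measured. It differs from compound 2 in one place: 2-methylprop-1-en-1-yl in place of isopropyl on a saturated chain carbon bound to an aromatic nitrogen.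

Among the compounds with values here, the only step measured so far, a number 12 percentage points higher from compound 1 to compound 3 (beyond the scatter), changes the group on the carbonyl carbon, not the chain on the aromatic nitrogen, so it does not bear directly on the change from compound 2 to compound 4; it shows only that one exchange on the carbonyl side gave a modest shift. Within the data shown here, no measured pair separates the isobutyl chain of compound 2 from any other chain at that position, so the direction for compound 4 rests on little. The author therefore expects a step from compound 2 to compound 4 that is small, about a number 8.9 percentage points higher from compound 2 to compound 4 (within the scatter), possibly within the scatter. For compound 4 the expected value in this assay is 22%, with a range from 6% to 45%.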

Compound 4, a percentage reported as inhibition, at one concentration (the size of the read-out at that concentration, not a potency): 74.3%
The estimate for compound 4 lay 52.3 percentage points below the measured number; measured number above the stated range.
By their numbers in this assay, from the lowest: compound 2; then compound 1; then compounds 3 and 4 (each within the scatter of the next).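

In this assay, the chain on the aromatic nitrogen proves to be a strong lever: with the rest of the molecule unchanged, exchanging isobutyl for 3-methylbut-2-en-1-yl gives a number 61.2 percentage points higher from compound 2 to compound 4 (beyond the scatter). Within the data shown here, the earlier compounds offered only a change on the carbonyl side, a number 12 percentage points higher from compound 1 to compound 3 (beyond the scatter), which is a modest step, so this is the first measured pair at the chain position, and its step is large. The entering chain carries a double bond outside aromatic rings and the leaving chain does not, neither has a ring, hydrogen-bond donors, hydrogen-bond acceptors or a net charge, and nothing available here accounts for the size of the step.

A saturated 3-methylbutyl chain at this place would be needed to tell whether the gain goes with the double bond or with the longer chain itself. On these data alone, it also remains open whether the same exchange gives a step of similar size when cyclopentyl or 4-methoxyphenyl sits on the carbonyl carbon.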